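The compounds below may be only part of what the source reports. "The series", "measured", "known", "first", "only" and "open" are said of these compounds alone.

Values measured in a physicochemical assay for lipophilicity, measured as octanol-water partition (a higher number here means a more lipophilic compound, a lower number a more polar compound), for the three compounds so far:

- Compound 1 `COc1cccc(C(=O)O[C@@H]2C[C@H](C)CC[C@H]2C(C)C)c1` gives 4.57
- Compound 2 `CC(C)[C@@H]1CC[C@@H](C)C[C@H]1OC(=O)c1ccc(Br)cc1` gives 5.61
- Compound 3 `CC(C)[C@@H]1CC[C@@H](C)C[C@H]1OC(=O)c1ccccc1` gives 4.82

On this assay compound 3 sits level with compound 1 within the scatter, and clearly under compound 2. The next compound to consider is compound 4 `Cc1ccccc1C(=O)O[C@@H]1C[C@H](C)CC[C@H]1C(C)C`, which carries methyl in place of hydrogen on an aromatic carbon, ortho to a large group (methyl in place of hydrogen on an aromatic carbon).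

Among the measured compounds shown here, two measured steps bear on this change, since each also swaps a hydrogen and another group on an aromatic carbon. Neither involves a methyl, so they serve only as a rough guide. The methoxy swap gave a small shift (a number 0.25 log units higher from compound 1 to compound 3 (within the scatter)), and the bromo swap gave a modest one (a number 0.79 log units lower from compound 2 to compound 3 (beyond the scatter)). In these two cases, removing the group never raised the number beyond the scatter, although compound 1 shows that such a swap can leave it effectively unchanged.

A modest rise is therefore expected on adding the methyl (a number 0.38 log units higher from compound 3 to compound 4 (beyond the scatter)). For compound 4 the estimated value is 5.2 (expected range 4.8 to 5.6).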

Compound 4, partition coefficient: 5.29
Compound 4: the middle estimate sits 0.09 log units below what was measured, within the range that was stated.
By their numbers in this assay, from the lowest: compounds 1 and 3 (each within the scatter of the next); then compound 4; then compound 2.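

In this assay, methyl on an aromatic carbon, ortho to a large group, gives a number 0.47 log units higher from compound 3 to compound 4 (beyond the scatter) and moves the number beyond the scatter. This change enters only 1 heavy atom, with 0 hydrogen-bond donors and 0 hydrogen-bond acceptors, so even the smallest carbon group can register at this place on the ring. Among the three swaps measured so far on an aromatic carbon, methyl and bromo each come with a step beyond the scatter, while methoxy, the swap linking compound 1 and compound 3, goes against that pattern and stays within it.

A single group at a single place cannot show whether the rise belongs to methyl itself or to this place, so a longer chain such as ethyl, or an amine or a carboxylic acid on the same carbon, would be needed to see how the number follows the group entering there, and methyl on another carbon of the ring would be needed to test the place. The reason for the rise also stays open, as nothing measured here accounts for it.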